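This account rests on a few compounds, and the source may have more. Where it says the series, first, only, none or still open, it means among the compounds named here.

For the measured compounds named here, in a functional assay on HCC 2998 cells (Homo sapiens) for inhibition (on this read-out higher numbers stand for weaker inhibition of growth and lower numbers for stronger inhibition of growth), only two compounds have numbers so far. Compound 1 `Nc1ccc(-c2nc3ccc(F)cc3s2)cc1I` gives 320 nM in this test, and compound 2 `Nc1ccc(-c2nc3ccccc3s2)cc1C(F)(F)F` gives 10700 nM in this test. Compound 2 therefore stands at the higher of the two numbers, which means the weaker inhibition of growth, and its gap to compound 1 lies beyond the usual scatter of repeated measurements.

The next compound to be measured is compound 3 `Nc1ccc(-c2nc3ccccc3s2)cc1F`. It carries fluoro in place of trifluoromethyl on an aromatic carbon, ortho to an amino group, and the counted change is fluoro in place of trifluoromethyl on an aromatic carbon in full.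

Going by the values given here, no measured pair shows this exchange on its own, so the size of the step cannot be read from the data. The only guide is that compound 1 reaches 320 nM in this assay and so shows that much lower numbers occur among these compounds. A fall in the number, beyond the scatter but uncertain in size, is expected, with the estimated step being a 5.4-fold lower number from compound 2 to compound 3 (0.73 log units; beyond the scatter) toward stronger inhibition. For compound 3 the expected value is 2000 nM with an estimated range from 200 nM to 15000 nM as its span.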

Compound 3, concentration for 50% growth inhibition: 100 nM
Compound 3: the middle estimate sits 20-fold (1.30 log units) above what was measured; the measured number lies below the stated range.
By their numbers in this assay, from the lowest: compound 3; then compound 1; then compound 2.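

Replacing trifluoromethyl with fluoro on this aromatic carbon, ortho to an amino group, gives in this assay a 110-fold lower number from compound 2 to compound 3 (2.03 log units; beyond the scatter), which shows that this one position can by itself carry a large change in growth inhibition. The earlier compounds shown here could not show this, as compound 1 and compound 2 differ in more than one place, so their gap could not be tied to any single group. Here the group with 1 heavy atom goes with the stronger inhibition of growth and the group with 4 heavy atoms with the weaker, but nothing measured among these compounds explains the size of the step.

A single pair cannot show whether the number follows the count of heavy atoms or something else, and chloro, methyl or a nitrile at the same position would help to separate these possibilities. On these data alone, it also remains open whether the same exchange would give a step of similar size on another core, such as the core of compound 1.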